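The source may report more compounds than this note shows. Statements on the series, on what has been measured and on what is new or still open speak of the compounds shown alone.

The study measures inhibition in a functional assay (Mus musculus) for inhibition, with a stated time of 5 days; on this read-out lower numbers stand for stronger inhibition and higher numbers for weaker inhibition. Compound 1, `O=C(O)/C=C/c1cn(-c2ccc(O)cc2)nc1-c1ccc(O)cc1`, is the simplest of the three measured compounds. In this assay compound 1 gives > 100000 nM, which is a limit of the assay and not a number. Compound 2, `O=C(O)/C=C/c1cn(-c2ccc(O)cc2)nc1-c1ccc(O)c(O)c1`, carries one extra hydroxy on an aromatic carbon. In this assay compound 2 gives > 100000 nM, again a limit. The step that the two limits leave unreadable from compound 1 to compound 2 therefore cannot be read, because of the limit of > 100000 nM in this assay, at which 2 of the 3 values shown sit. Compound 3, `O=Cc1cn(-c2ccc(O)cc2)nc1-c1cc(O)ccc1O`, has an aldehyde in place of the acrylic acid and a different hydroxy pattern, and in this assay compound 3 gives 43000 nM.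

Compound 2 thus sits at the limit, with no number of its own.

Compound 4, `O=C(O)/C=C/c1cn(-c2ccc(O)cc2)nc1-c1cccc(O)c1`, is not yet measured. It differs from compound 2 as follows: hydrogen in place of hydroxy on an aromatic carbon. No measured step covers this change; the one measured step runs in the opposite direction and its size is not readable, so nothing shown points to a gain or a loss beyond the scatter. Compound 4 is therefore expected to stay close to compound 2, a step that the limit leaves unreadable from compound 2 to compound 4. The estimate for compound 4 is 150000 nM, within a range from 40000 nM to 600000 nM.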

Compound 4, half-maximal inhibitory concentration: > 100000 nM
Compound 4: a limit, no number; the forecaster's own chance of this, stated with the estimate: 80%; the middle value lies beyond the limit too.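

No step can be read among compound 1, compound 2 and compound 4, because in this assay all three give a limit and not a number: the limit of > 100000 nM in this assay, at which 3 of the 4 values shown sit.

The compounds shown leave open whether adding, removing or shifting a hydroxy on an aromatic ring changes inhibition in these three compounds at all.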